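The source may report more compounds than this note shows. Statements on the series, on what has been measured and on what is new or still open speak of the compounds shown alone.

In a functional assay on HOP-62 cells (Homo sapiens) for inhibition, read by sulforhodamine B assay, with a stated time of 48 h, tested at 10 uM (a lower number here means less inhibition of growth, a higher number more inhibition of growth at the concentration tested), compound 1 (`CC(=O)c1ccc(NC(=O)Cn2nc(-c3ccc(Cl)cc3)nc2N)cc1`) gives 15.1% and compound 2 (`C/C(=N/O)c1ccc(NC(=O)Cn2nc(C(F)(F)F)nc2N)cc1`) gives 9.21%. These two values lie within the usual scatter of each other, so compound 2 stands level with compound 1. Compound 3 (`C/C(=N/O)c1ccc(NC(=O)Cn2nc(-c3ccccc3)nc2N)cc1`) carries phenyl in place of trifluoromethyl on an aromatic carbon. For the measured compounds named here, no measured step shows what this change does in this assay, so only a modest shift is expected. The expected step, a number 3.8 percentage points higher from compound 2 to compound 3 (within the scatter), is small, points towards more inhibition of growth and stays within the scatter. Compound 3 is estimated at 13%, with a range of 2% to 32%.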

Compound 3, percent growth inhibition at one concentration: 17.7%
Compound 3: middle estimate off by 4.7 percentage points, on the low side; low and high end bracket the measured number.
By their numbers in this assay, from the lowest: compounds 2, 1 and 3 (each within the scatter of the next).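

Phenyl in place of trifluoromethyl on this aromatic carbon gives a number 8.5 percentage points higher from compound 2 to compound 3 (within the scatter) in this assay. For the compounds shown here, this is the first measured step at this position, and it shows that exchanging these two groups, one with a ring and one without, leaves growth inhibition level at the concentration tested. Nothing available explains the result. On these data alone, whether an amine, a carboxylic acid or a longer alkyl chain on this carbon would move the number beyond the scatter remains open, as does the effect of the same exchange on other cell lines.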